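Methoxy for trifluoromethyl on two related cores

The source may report more compounds than this note shows. Statements on the series, on what has been measured and on what is new or still open speak of the compounds shown alone.

Compound 1 `O=S(=O)(/C=C/c1ccc(O)c(O)c1)Cc1ccc(C(F)(F)F)cc1` gives 15900 nM in a functional assay on BV-2 cells (Mus musculus) for inhibition, read by Griess assay, with stated times of 3 h and 24 h; on this read-out higher numbers stand for weaker inhibition and lower numbers for stronger inhibition. Compound 2 `COc1ccc(CS(=O)(=O)/C=C/c2ccc(O)c(O)c2)cc1` gives 11900 nM in this assay; the change is methoxy in place of trifluoromethyl on an aromatic carbon and the step is a 1.3-fold lower number from compound 1 to compound 2 (0.13 log units; within the scatter). Compound 3 `[O-][S+](/C=C/c1ccc(O)c(O)c1)Cc1ccc(C(F)(F)F)cc1` gives 15500 nM in this assay; the difference between the core of compound 3 and the core of compound 1 is not broken down here, and the two values lie within the scatter of each other. Compound 4 `COc1ccc(C[S+]([O-])/C=C/c2ccc(O)c(O)c2)cc1` differs from compound 3 by methoxy in place of trifluoromethyl on an aromatic carbon, the same change as that from compound 1 to compound 2. The step is expected to be a 1.3-fold lower number from compound 3 to compound 4 (0.11 log units; within the scatter), resting on the earlier step of a 1.3-fold lower number from compound 1 to compound 2 (0.13 log units; within the scatter) being within the scatter. Compound 4 is therefore expected to give 12000 nM in this assay, estimated between 7000 nM and 22000 nM.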

Compound 4, half-maximal inhibitory concentration: 33000 nM
The estimate for compound 4 lay 2.8-fold (0.44 log units) below the measured number, outside the stated range (above it).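

On the core of compound 3, methoxy in place of trifluoromethyl on an aromatic carbon gives a 2.1-fold higher number from compound 3 to compound 4 (0.33 log units; beyond the scatter) in this assay. The change therefore does not carry over as a fixed step from the core of compound 1, where its step lies within the scatter: the same change on two cores in this assay, a 1.3-fold lower number (0.13 log units; within the scatter) from compound 1 to compound 2 and a 2.1-fold higher number (0.33 log units; beyond the scatter) from compound 3 to compound 4, 2.8-fold (0.45 log units) apart, beyond the scatter of two such steps

This rests on a single pair per core and a modest new step, so it shows that the outcome of this change depends on the core, but not why, nor what it would do on a further core. The compounds shown leave open whether the two cores also part for other groups on that aromatic carbon, such as an amine or a carboxylic acid.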